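Replacing methyl with trifluoromethyl in the series

A few compounds are considered here, and "the series" means these few. Any claim that something is new, unique, unknown or untested is made for them only; others in the source may bear on it.

Compound 1 `Cc1cccc(-c2ccc(C(O)CCCCCO)cc2)c1`: > 100000 nM (a limit)
Compound 2 `Cc1ccc(-c2ccc(C(O)CCCCCO)cc2)cc1`: 22000 nM

Within the data shown here, in a functional assay on J774 cells (Mus musculus) for cytotoxicity, read by resazurin assay (a higher number here means a weaker inhibitor, a lower number a stronger inhibitor), compound 2 gives 22000 nM, the only actual number so far. The reading for compound 1 is a limit, not a number: the limit of > 100000 nM in this assay, at which 1 of the 2 values shown sits.

Compound 3 `OCCCCCC(O)c1ccc(-c2ccc(C(F)(F)F)cc2)cc1` has trifluoromethyl in place of methyl on an aromatic carbon, para to a large group: trifluoromethyl in place of methyl on an aromatic carbon.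

Among the measured compounds shown here, only one measured step bears on this change: an at least 4.5-fold lower number from compound 1 to compound 2 (0.65 log units; beyond the scatter). That step lies beyond the scatter, but it moves the methyl group and does not replace it, so it shows only that this assay can respond to a change at this end of the molecule. For the measured compounds named here, no measured step replaces methyl with another group. The expected change is therefore small and within the scatter: a 1.5-fold lower number from compound 2 to compound 3 (0.17 log units; within the scatter). For compound 3 the estimated value is 15000 nM, with an expected range from 6000 nM to 45000 nM.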

Compound 3, half-maximal inhibitory concentration: 13000 nM
Estimate against measurement, compound 3: 1.2-fold (0.06 log units) above, and the stated range covers the measured number.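

In this assay, replacing methyl with trifluoromethyl on an aromatic carbon, para to a large group, gives a 1.7-fold lower number from compound 2 to compound 3 (0.23 log units; within the scatter), so the readings of these two compounds cannot be told apart. This is the first step in the series that changes the group itself at this position, and it contrasts with moving methyl, which gave an at least 4.5-fold lower number from compound 1 to compound 2 (0.65 log units; beyond the scatter); among the compounds shown, only the move lies beyond the scatter. Nothing measured here bears on why the exchange of methyl for trifluoromethyl leaves the two readings within the scatter.

On these data alone, whether an amine, a carboxylic acid or a nitrile in the same place would also read alike remains open. So does whether trifluoromethyl would follow methyl in the placement seen in compound 1, and whether a longer chain on the other end of the molecule would alter this picture.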